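The source may hold more compounds than are shown below. What is called first, only, known or untested is meant among the compounds shown, and "the series" means these compounds.

Compound 2 `COC(=O)Nc1c(C)nc2c(OCc3ccccc3)cccn12` has the lowest number in this small set: in a functional assay on the whole organism with Rattus norvegicus as the target, at a dose of 40 mg/kg by the intraperitoneal route (a higher number here means more inhibition at the dose given (going by the name of the read-out), a lower number less inhibition), compound 2 gives 0%. Compound 3 `Cc1nc2c(OCc3ccccc3)cccn2c1NC(=O)OCc1ccccc1` comes nearest, and in this assay compound 3 gives 8%; the change from one to the other, phenyl in place of hydrogen on a saturated chain carbon bound to an oxygen next to a carbonyl group, produced a number 8 percentage points higher from compound 2 to compound 3 (within the scatter). Compound 1 `Cc1nc2c(OCCc3ccccc3)cccn2c1N` carries no methoxycarbonyl and also differs from compound 2 elsewhere. In this assay compound 1 gives 56%. Among the compounds with values here, that number lies far beyond the scatter above the one of compound 2.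

Compound 4 `Cc1nc2c(OCc3ccccc3)cccn2c1NC(C)C` arises from compound 2 by isopropyl in place of methoxycarbonyl on a nitrogen on an aromatic ring. Within the data shown here, no measured step follows exactly this change. The step from compound 2 to compound 3, which kept the methoxycarbonyl-type carbamate and varied only its ester end, stayed within the scatter, so altering that end alone does little. Removing the methoxycarbonyl altogether moves compound 4 toward the pattern of compound 1, which lacks it and has the higher number in this assay, though compound 1 differs in more than one place, so the inference is uncertain. Compound 4 is therefore expected to rise in this assay, with an estimated step of a number 35 percentage points higher from compound 2 to compound 4 (beyond the scatter). The estimate for compound 4 is 35%, with a range from 5% to 65%.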

Compound 4, a percentage reported as inhibition, in the whole organism at one dose (the size of the read-out at that dose, not a potency): 18%
Compound 4: the middle estimate sits 17 percentage points above what was measured; the measured number falls inside the stated range.
By their numbers in this assay, from the lowest: compounds 2, 3 and 4 (each within the scatter of the next, the first and the last beyond it); then compound 1.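

Putting isopropyl in place of methoxycarbonyl on this nitrogen gives, in this assay, a number 18 percentage points higher from compound 2 to compound 4 (beyond the scatter) and is the first change among these compounds to pass the scatter. The earlier change at the far end of the carbamate gave a number 8 percentage points higher from compound 2 to compound 3 (within the scatter) and did not, so the nitrogen substituent itself can shift the number, though only modestly. No measurement bears on why this step occurs.

On these data alone, it remains open whether an ethyl group or a longer alkyl chain on this nitrogen would raise the number further, and whether an acetyl group, which keeps a carbonyl there, would behave like the carbamates. The free amine on the core of compound 4 is also absent, so the contribution of the substituent cannot be separated from the other difference in compound 1.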